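This account rests on a few compounds, and the source may have more. Where it says the series, first, only, none or still open, it means among the compounds named here.

Compound 1 `O=C1OC[C@H](Cc2ccccc2)[C@H]1Cc1ccc(Cl)c(Cl)c1` gives 19000 nM
Compound 2 `COc1cc(C[C@H]2COC(=O)[C@@H]2Cc2ccc(Cl)c(Cl)c2)ccc1O` gives 36000 nM
Compound 3 `Oc1ccccc1C[C@H]1COC[C@@H]1Cc1ccc(Cl)c(Cl)c1` gives 34000 nM

All three compounds were tested in a functional assay on HL-60 cells (Homo sapiens) for cytotoxicity, read by WST assay, with a stated time of 48 h; a higher number here means that more compound is needed for the effect, a lower number that less compound is needed. Compound 3 , at 34000 nM, stands within the usual scatter of both other compounds, so no order can be drawn between it and either of them.

The next compound to consider is compound 4 `CCOc1ccccc1C[C@H]1COC[C@@H]1Cc1ccc(Cl)c(Cl)c1`. It is compound 3 with one change: ethyl in place of hydrogen on an oxygen on an aromatic ring, so that hydroxy becomes ethoxy (ethyl in place of hydrogen on an oxygen on an aromatic ring).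

Among the measured compounds shown here, no pair of measured compounds differs in only one place, so the data contain no direct precedent for this change. For the measured compounds named here, the only guide is the spread of values across structures that differ in more than one place: compound 1 gives 19000 nM and compound 2 gives 36000 nM, and these values lie close to the value of compound 3 at 34000 nM. A small change is therefore the reasonable expectation, with a slightly lower number at most and nothing beyond the scatter.

The estimated size of the change is a 1.4-fold lower number from compound 3 to compound 4 (0.13 log units; within the scatter), which would remain within the scatter.

For compound 4 the estimated value is 25000 nM, with an expected range from 10000 nM to 60000 nM.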

Compound 4, half-maximal effective concentration: 29000 nM
The estimate for compound 4 lay 1.2-fold (0.06 log units) below the measured number; the range from low to high includes it.
By their numbers in this assay, from the lowest: compounds 1, 4, 3 and 2 (each within the scatter of the next).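

In this assay, putting ethyl in place of the hydrogen on the oxygen on the aromatic ring, so that hydroxy becomes ethoxy, gives a 1.2-fold lower number from compound 3 to compound 4 (0.07 log units; within the scatter). Among the compounds shown here, this is the first pair that differs in one place only, so the change can now be read directly instead of being inferred from compounds that differ in several places: in this assay, the hydroxy and ethoxy compounds cannot be told apart, and at this oxygen the hydrogen can give way to ethyl without a difference that stands out from repeat measurements. Nothing measured alongside these numbers helps to explain this outcome.

A single pair cannot show whether this holds for other groups at the same place, such as a longer chain like butyl on the same oxygen, or an amine or a carboxylic acid in place of the hydroxy. It also leaves open whether any change at this place can move the number beyond the scatter, or whether the same exchange would behave alike on the core of compound 1.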